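A few compounds are considered here, and "the series" means these few. Any claim that something is new, unique, unknown or untested is made for them only; others in the source may bear on it.

Compound 1, `CCn1cc(-c2nc3ccccc3o2)c(=O)c2cc(F)c(Cl)cc21`, and compound 3, `CCn1cc(-c2nc3ccc([N+](=O)[O-])cc3o2)c(=O)c2cc(F)c(Cl)cc21`, share one core and differ only where (nitro in place of hydrogen on an aromatic carbon). In a functional assay on KB cells (Homo sapiens) for cytotoxicity, read by MTT assay, with a stated time of 48 h (a lower number here means a stronger inhibitor, a higher number a weaker inhibitor), compound 1 gives 10200 nM, while compound 3 gives 500 nM, so that a 20-fold lower number from compound 1 to compound 3 (1.31 log units; beyond the scatter). Compound 2, `CCn1cc(-c2nc3ccccc3s2)c(=O)c2cc(F)c(N3CCNCC3)nc21`, is built on a different core; the difference between the two cores is not broken down here. In this assay compound 2 gives 2400 nM, which places it between compound 1 and compound 3.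

Compound 4, `CCn1cc(-c2nc3ccc([N+](=O)[O-])cc3s2)c(=O)c2cc(F)c(N3CCNCC3)nc21`, stands to compound 2 as compound 3 stands to compound 1: it carries nitro in place of hydrogen on an aromatic carbon. The place is the same in both pairs, so the change is the same one, only made on the core of compound 2. Among the compounds with values here, the only guide to its size is the step from compound 1 to compound 3, and it is not known whether the core of compound 2 answers in the same way; a somewhat smaller step is therefore expected, an 8.0-fold lower number from compound 2 to compound 4 (0.90 log units; beyond the scatter), because the step of a 20-fold lower number from compound 1 to compound 3 (1.31 log units; beyond the scatter) rests on a single pair. Compound 4 is thus estimated to give 300 nM in this assay, most likely between 80 nM and 1500 nM.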

Compound 4, half-maximal inhibitory concentration: 179000 nM
Beside the measured number, compound 4's estimate is 600-fold (2.78 log units) below it, outside the stated range (above it).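

In this assay, nitro in place of hydrogen on an aromatic carbon gives a 75-fold higher number from compound 2 to compound 4 (1.87 log units; beyond the scatter), so the change that made compound 3 a stronger inhibitor than compound 1 makes compound 4 a weaker inhibitor than compound 2. Set side by side, the two steps disagree in direction, and the effect of this change does not carry from one core to the other in this series: the same change on two cores in this assay, a 20-fold lower number (1.31 log units; beyond the scatter) from compound 1 to compound 3 and a 75-fold higher number (1.87 log units; beyond the scatter) from compound 2 to compound 4, 1500-fold (3.18 log units) apart, beyond the scatter of two such steps. This does not show which feature of the two cores reverses the step, since the cores differ in more than one place and each is represented by a single pair, so no rule for any further core follows.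

The compounds shown leave open which part of the core decides the direction of the step, as no pair separates those parts one at a time. They also leave open whether an amine or a nitrile on the same aromatic carbon would follow the step seen on the core of compound 1 or the one seen on the core of compound 2.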